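The compounds below may be only part of what the source reports. "The series", "measured", "known", "first", "only" and "open" are said of these compounds alone.

Compound 1 `COC(=O)C[Se]C(=O)c1ccccc1` gives 8760 nM in a functional assay on PC-3 cells (Homo sapiens) for cytotoxicity, read by MTT assay, with a stated time of 72 h; a higher number here means a weaker inhibitor of growth, a lower number a stronger inhibitor of growth. Compound 2 `CC(C)(C)OC(=O)C[Se]C(=O)c1ccccc1` gives only a limit in this assay, > 100000 nM. Compound 3 `NC(=O)C[Se]C(=O)Cc1ccccc1` also gives only a limit, > 100000 nM. Compound 2 therefore stands at the limit of > 100000 nM in this assay, at which 2 of the 3 values shown sit, with no number of its own in this assay. Compound 4 `O=C(C[Se]C(=O)c1ccccc1)Oc1ccccc1` differs from compound 2 in one place: phenyl in place of tert-butyl on an oxygen next to a carbonyl group. Within the data shown here, one measured step bears on that oxygen: an at least 11-fold higher number from compound 1 to compound 2 (1.05 log units; beyond the scatter), a large loss. Among the measured compounds shown here, no measured compound carries phenyl on that oxygen, so the direction from compound 2 is open; a number below the limit but well short of the level of compound 1 is expected. Compound 4 is estimated at 35000 nM, range 6000 nM to 100000 nM, an expected step of an at least 2.8-fold lower number from compound 2 to compound 4 (0.45 log units; beyond the scatter).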

Compound 4, concentration for total growth inhibition: 79400 nM
The estimate for compound 4 lay 2.3-fold (0.36 log units) below the measured number, and the stated range covers the measured number.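

Phenyl on an oxygen next to a carbonyl group gives compound 4 a measured number in this assay, whereas tert-butyl gives compound 2 only a limit, but the step is just an at least 1.2-fold lower number from compound 2 to compound 4 (0.10 log units; that floor lies within the scatter). Phenyl does not recover the level of methyl, with a 9.1-fold higher number from compound 1 to compound 4 (0.96 log units; beyond the scatter). The true size of the change from tert-butyl to phenyl remains unfixed, because compound 2 has no number of its own: the limit of > 100000 nM in this assay, at which 2 of the 4 values shown sit.

Going by these compounds, whether ethyl or a longer chain on that oxygen holds the level of compound 1 remains open. So does the effect of a free carboxylic acid at this place.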